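Moving a methoxyphenyl: what compound 4 should show

A few compounds are considered here, and "the series" means these few. Any claim that something is new, unique, unknown or untested is made for them only; others in the source may bear on it.

Going by the values given here, in a functional assay on HepG2 cells (Homo sapiens) for cytotoxicity, read by sulforhodamine B assay, with a stated time of 48 h (a lower number here means a stronger inhibitor, a higher number a weaker inhibitor), compound 3 (`COc1ccccc1/C=C/C(=O)c1cccc(-c2cccc(F)c2)c1`) gives 15400 nM as the highest of the three numbers so far. Compound 2 (`O=C(/C=C/c1cccc(Br)c1)c1cccc(-c2cccc(F)c2)c1`) gives 6980 nM and compound 1 (`COc1ccc(/C=C/C(=O)c2cccc(-c3ccc(F)cc3)c2)cc1`) gives 5650 nM in the same read-out, so both lie lower than compound 3.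

Compound 4 (`COc1ccc(/C=C/C(=O)c2cccc(-c3cccc(F)c3)c2)cc1`) has the same atoms as compound 3, joined differently. The difference (4-methoxyphenyl in place of 2-methoxyphenyl on a double-bonded chain carbon bound to a double-bonded chain carbon) puts 4-methoxyphenyl in place of 2-methoxyphenyl on a double-bonded chain carbon bound to a double-bonded chain carbon.

Among the compounds with values here, only one measured step touches this place (a 2.2-fold higher number from compound 2 to compound 3 (0.34 log units; beyond the scatter)) and it is modest, with 2-methoxyphenyl entering in place of 3-bromophenyl. That step raised the number on arrival of the group that now leaves. Within the data shown here, compound 1 already carries the entering 4-methoxyphenyl and gives 5650 nM but differs from compound 4 in where its fluorine sits, so no measured pair tests the change directly.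

A modest fall in the number is therefore expected (a 2.4-fold lower number from compound 3 to compound 4 (0.37 log units; beyond the scatter)) and is only an estimate. Compound 4 is estimated at 6500 nM with an expected range from 3000 nM to 14000 nM in this assay when measured.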

Compound 4, half-maximal inhibitory concentration: 1720 nM
For compound 4 the middle estimate is 3.8-fold (0.58 log units) above the measured one; measured number below the stated range.
By their numbers in this assay, from the lowest: compound 4; then compounds 1 and 2 (each within the scatter of the next); then compound 3.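

In this assay the methoxy group is not interchangeable between these two phenyl rings: with the same atoms joined differently, 4-methoxyphenyl in place of 2-methoxyphenyl on a double-bonded chain carbon bound to a double-bonded chain carbon gives a 9.0-fold lower number from compound 3 to compound 4 (0.95 log units; beyond the scatter) and is the largest step seen so far in the series. Going by these compounds alone, the earlier compounds showed only that 2-methoxyphenyl raised the number relative to 3-bromophenyl, whereas 4-methoxyphenyl lowers it relative to the same group, with a 4.1-fold lower number from compound 2 to compound 4 (0.61 log units; beyond the scatter) and compound 4 now the strongest inhibitor of the four. They also gave no reading of the fluorine's place, which the step of 3-fluorophenyl in place of 4-fluorophenyl on an aromatic carbon now supplies as a 3.3-fold lower number from compound 1 to compound 4 (0.52 log units; beyond the scatter) and shows to matter as well.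

No measurement shown here accounts for any of these steps. As far as these compounds go, it remains open whether the gain from 4-methoxyphenyl would be the same size with 4-fluorophenyl on the other ring, and whether an amine or a carboxylic acid in place of the methoxy group would keep the low number of compound 4.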